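This account rests on a few compounds, and the source may have more. Where it says the series, first, only, none or still open, it means among the compounds named here.

Compound 3 `COc1ccc2[nH]c(-c3ccccc3)c(/C=C(\C#N)S(=O)(=O)c3ccccc3)c2c1` gives the highest number among the three measured compounds in a functional assay on CAKI-1 cells (Homo sapiens) for inhibition, read by sulforhodamine B assay, with a stated time of 48 h (on this read-out lower numbers stand for stronger inhibition of growth and higher numbers for weaker inhibition of growth), where compound 3 gives 4500 nM. Compound 2 `O=C(/C(=C\c1c(-c2ccccc2)[nH]c2ccccc12)S(=O)(=O)c1ccccc1)c1ccccc1` gives 3100 nM in this assay, a value within the scatter of compound 3. Compound 1 `COc1ccc(-c2[nH]c3ccccc3c2/C=C(\C#N)S(=O)(=O)c2ccccc2)cc1` gives 997 nM in this assay, a lower number that lies beyond the scatter. Compound 4 `N#C/C(=C\c1c(-c2ccccc2)[nH]c2ccccc12)S(=O)(=O)c1ccccc1` differs from compound 3 by hydrogen in place of methoxy on an aromatic carbon. Among the compounds with values here, no measured pair shows this change directly, so the expected step from compound 3 to compound 4 is a 1.8-fold lower number from compound 3 to compound 4 (0.26 log units; within the scatter), leaning toward a lower number but not clearly beyond the scatter. Compound 4 is therefore estimated at 2500 nM in this assay, with a range from 800 nM to 8000 nM.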

Compound 4, concentration for 50% growth inhibition: 5500 nM
Compound 4: the middle estimate sits 2.2-fold (0.34 log units) below what was measured, within the range that was stated.
By their numbers in this assay, from the lowest: compound 1; then compounds 2, 3 and 4 (each within the scatter of the next).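

In this assay replacing methoxy with hydrogen at this aromatic carbon of the fused system leaves the number within the scatter (a 1.2-fold higher number from compound 3 to compound 4 (0.09 log units; within the scatter)), so this position does not separate the two groups. Cyano and benzoyl on the double-bonded chain carbon are not separated either (a 1.8-fold higher number from compound 2 to compound 4 (0.25 log units; within the scatter)). The methoxy of compound 1, placed elsewhere on the core, does stand clear of hydrogen (a 5.5-fold higher number from compound 1 to compound 4 (0.74 log units; beyond the scatter)). Nothing given here bears on the cause of these steps. From the compounds shown here alone, whether an amine or hydroxyl at this aromatic carbon would change the number remains open.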